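The compounds below may be only part of what the source reports. "The series", "measured", "known", "first", "only" and "open" are said of these compounds alone.

Measured compounds:
compound 1, `NC(=O)c1c(NC(=O)c2ccccc2Cl)sc2c1CCNC2` — 28700 nM
compound 2, `NC(=O)c1c(NC(=O)c2ccccc2F)sc2c1CCN(Cc1cccc(Cl)c1)C2` — 23300 nM

Of the compounds shown here, two built on a shared core have been tested in a functional assay on MKN-74 cells (Homo sapiens) for antiproliferative activity, with a stated time of 24 h; a lower number here means a stronger inhibitor, a higher number a weaker inhibitor. In this assay compound 1 gives 28700 nM, and in this assay compound 2 gives 23300 nM. Compound 1 has the higher of the two numbers, but the gap to compound 2 lies within the scatter, so the two compounds cannot be told apart on these data; both are weak inhibitors.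

The next compound is compound 3, `NC(=O)c1c(NC(=O)c2ccccc2Cl)sc2c1CCN(C(=O)Nc1ccccc1Cl)C2`. It differs from compound 1 in one place: (2-chlorophenyl)carbamoyl in place of hydrogen on an amine nitrogen in a ring. Among the compounds with values here, no step between measured compounds bears on this change, since compound 2 differs from compound 1 at the same nitrogen and also in its halogen, and its value stays within the scatter of compound 1. The step from compound 1 to compound 3 in this assay is therefore expected to be modest, if anything a lowering of the number, and may not exceed the scatter; the expected step is a 1.9-fold lower number from compound 1 to compound 3 (0.28 log units; within the scatter). Compound 3 is expected to give about 15000 nM in this assay, within a range from 5000 nM to 45000 nM.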

Compound 3, half-maximal inhibitory concentration: 16300 nM
The estimate for compound 3 lay 1.1-fold (0.04 log units) below the measured number, and the stated range covers the measured number.
By their numbers in this assay, from the lowest: compounds 3, 2 and 1 (each within the scatter of the next).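

Within the data shown here, compound 3 gives the first reading of a single change at the amine nitrogen in the ring, with the rest of compound 1 left as it is. In this assay, placing (2-chlorophenyl)carbamoyl on that nitrogen in place of hydrogen gives a 1.8-fold lower number from compound 1 to compound 3 (0.25 log units; within the scatter) and therefore cannot be told from no effect, so this added group, with its aromatic ring, does not produce a measurable gain or loss here. Compound 3, at 16300 nM, is a weak inhibitor, as is compound 1, and nothing shown offers an explanation for the result.

From the compounds shown here alone, it remains open whether any other group on this nitrogen would move the number beyond the scatter, such as a methyl group, an acetyl group or a carbamoyl bearing a longer alkyl chain instead of the 2-chlorophenyl ring. Going by these compounds, it is equally open whether an amine or a carboxylic acid on that phenyl ring, in place of the chlorine, would separate such a compound from compound 1 or compound 3.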